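This account rests on a few compounds, and the source may have more. Where it says the series, first, only, none or still open, it means among the compounds named here.

Compound 1 `C=C1[C@@H](OC(C)=O)C[C@@H]2[C@](C)(COC=O)[C@H](OC(C)=O)CC[C@@]2(C)[C@@H]1C[C@@H](Nc1ccc(O)cc1)C1=CCOC1=O`, 29100 nM
Compound 2 `C=C1[C@@H](OC(C)=O)C[C@@H]2[C@](C)(COC=O)[C@H](OC(C)=O)CC[C@@]2(C)[C@@H]1C[C@@H](Nc1ccccc1)C1=CCOC1=O`, 25800 nM
Compound 3 `C=C1[C@@H](OC(C)=O)C[C@@H]2[C@](C)(CO[Si](C)(C)C(C)(C)C)[C@H](OC(C)=O)CC[C@@]2(C)[C@@H]1C[C@@H](Nc1ccccc1)C1=CCOC1=O`, 4500 nM

The three measured compounds were tested in a functional assay on A549 cells (Homo sapiens) for cytotoxicity, read by sulforhodamine B assay; a higher number here means a weaker inhibitor, a lower number a stronger inhibitor. Compound 2 and compound 1 differ only by hydroxy in place of hydrogen on an aromatic carbon, and that change gave a 1.1-fold higher number from compound 2 to compound 1 (0.05 log units; within the scatter). Compound 3 differs from compound 2 by a group of 7 heavy atoms (6 carbon, 1 silicon; no ring) in place of a group of 2 heavy atoms (1 carbon, 1 oxygen; no ring), on an oxygen on a saturated carbon, which gave a 5.7-fold lower number from compound 2 to compound 3 (0.76 log units; beyond the scatter); compound 3 thus gives the lowest number of the three. Compound 4 `C=C1[C@@H](OC(C)=O)C[C@@H]2[C@](C)(CO[Si](C)(C)C(C)(C)C)[C@H](OC(C)=O)CC[C@@]2(C)[C@@H]1C[C@@H](Nc1ccc(O)cc1)C1=CCOC1=O` is not yet measured. It differs from compound 3 by hydroxy in place of hydrogen on an aromatic carbon, the same change as between compound 2 and compound 1, on the core of compound 3. Because a 1.1-fold higher number from compound 2 to compound 1 (0.05 log units; within the scatter) lay within the scatter, compound 4 is expected to stay close to compound 3, with an expected step of a 1.1-fold higher number from compound 3 to compound 4 (0.05 log units; within the scatter). Compound 4 is estimated at 5000 nM, most likely between 2500 nM and 10000 nM.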

Compound 4, half-maximal inhibitory concentration: 5090 nM
For compound 4 the middle estimate is 1.0-fold (0.01 log units) below the measured one; the range from low to high includes it.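

In this assay, hydroxy in place of hydrogen on the aromatic ring, on the core bearing the larger silicon-containing group, gave a 1.1-fold higher number from compound 3 to compound 4 (0.05 log units; within the scatter), matching the earlier step: the same change on two cores in this assay, a 1.1-fold higher number (0.05 log units; within the scatter) from compound 2 to compound 1 and a 1.1-fold higher number (0.05 log units; within the scatter) from compound 3 to compound 4, 1.0-fold (0.00 log units) apart, within the scatter of two such steps

The larger silicon-containing group in place of the smaller group on the oxygen, now with 4-hydroxyphenyl present, gave a 5.7-fold lower number from compound 1 to compound 4 (0.76 log units; beyond the scatter), again matching the earlier step: the same change on two cores in this assay, a 5.7-fold lower number (0.76 log units; beyond the scatter) from compound 2 to compound 3 and a 5.7-fold lower number (0.76 log units; beyond the scatter) from compound 1 to compound 4, 1.0-fold (0.00 log units) apart, within the scatter of two such steps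

Across these four compounds each change therefore carried over between the two cores at the same size, but this rests on one pair of cores in this assay and does not show that it would hold on any other core.

From the compounds shown here alone, it remains open whether a methoxy group, an amine or a carboxylic acid in the hydroxy position would also leave the number within the scatter. Going by these compounds, it is also open whether a free hydroxymethyl group or a longer alkyl chain on that oxygen would follow the silicon-containing group.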